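The source may hold more compounds than are shown below. What is called first, only, known or untested is meant among the compounds shown, and "the series" means these compounds.

Measured so far:
- compound 1 `N[C@@H](CC(=O)OC[C@H]1O[C@@H](n2cc(F)c(=O)[nH]c2=O)C[C@@H]1O)C(=O)O` — 3600000 nM
- compound 2 `N[C@@H](CCC(=O)O[C@H]1C[C@H](n2cc(F)c(=O)[nH]c2=O)O[C@@H]1CO)C(=O)O` — 2500000 nM

In a functional assay on MIA PaCa-2 cells (Homo sapiens) for inhibition, read by MTT assay, with a stated time of 24 h (on this read-out higher numbers stand for weaker inhibition of growth and lower numbers for stronger inhibition of growth), compound 1 gives 3600000 nM and compound 2 gives 2500000 nM; the two numbers lie within the scatter of each other, so compound 2 stands level with compound 1 and nothing separates them.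

Compound 3 `CC(C)[C@H](N)C(=O)O[C@H]1C[C@H](n2cc(F)c(=O)[nH]c2=O)O[C@@H]1CO` is not yet measured. It differs from compound 2 in one place: 1-amino-2-methylpropyl in place of 3-amino-3-carboxypropyl on a carbonyl carbon.

Among the measured compounds shown here, no step between measured compounds is known, so nothing in the numbers points in either direction. The change from 3-amino-3-carboxypropyl to 1-amino-2-methylpropyl is expected to give a step from compound 2 to compound 3 of a 1.3-fold lower number from compound 2 to compound 3 (0.10 log units; within the scatter), none beyond the scatter. Compound 3 is therefore estimated at 2000000 nM, with a range of 600000 nM to 6000000 nM.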

Compound 3, concentration for 50% growth inhibition: 2600000 nM
The estimate for compound 3 lay 1.3-fold (0.11 log units) below the measured number, within the range that was stated.
By their numbers in this assay, from the lowest: compounds 2, 3 and 1 (each within the scatter of the next).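

In this assay the exchange on a carbonyl carbon gives a 1.0-fold higher number from compound 2 to compound 3 (0.02 log units; within the scatter), so compound 2 and compound 3 stand level. Among the compounds shown here, this is the first step read at this position, and it shows that 1-amino-2-methylpropyl and 3-amino-3-carboxypropyl cannot be told apart here, although only the latter carries a carboxy group. No measured property bears on this result.

Open, as far as these compounds go, is whether a simple alkyl chain lacking the amine, or a longer chain, on this carbonyl carbon would separate from compound 2 beyond the scatter.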